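A few compounds are considered here, and "the series" means these few. Any claim that something is new, unique, unknown or untested is made for them only; others in the source may bear on it.

Measured so far in a functional assay on EOL1 cells (Homo sapiens) for inhibition, read by fluorescence, with a stated time of 72 h; on this read-out higher numbers stand for weaker inhibition of growth and lower numbers for stronger inhibition of growth:

compound 1 `CCCCCCn1cnc2c(Nc3ccc(O)cc3)nc(N[C@H]3CC[C@H](N)CC3)nc21` gives 190 nM
compound 2 `CC(C)CCn1cnc2c(NCc3cccc(Cl)c3)nc(N[C@H]3CC[C@H](N)CC3)nc21` gives 1330 nM
compound 3 `COc1ccc(Cn2cnc3c(Nc4cccc(Cl)c4)nc(N[C@H]4CC[C@H](N)CC4)nc32)cc1` gives 530 nM

Compound 2 holds the highest of the three numbers in this assay. The nearest is compound 3, a gap beyond the usual scatter; the furthest is compound 1, also beyond it. Compound 1 and compound 3 both carry their ring straight on the nitrogen, while compound 2 reaches it through a benzyl, and both of them give lower numbers than compound 2.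

Compound 4 `COc1ccc(Nc2nc(N[C@H]3CC[C@H](N)CC3)nc3c2ncn3CCC(C)C)c(OC)c1` is not yet measured. It differs from compound 2 in one place:

2,4-dimethoxyphenyl in place of 3-chlorobenzyl on a nitrogen on an aromatic ring

Within the data shown here, no measured pair isolates this change, so its size is not known from a direct step. Given that compound 1 and compound 3, each with a ring straight on that nitrogen, sit below compound 2, a downward step in this assay beyond the scatter is expected, a 3.3-fold lower number from compound 2 to compound 4 (0.52 log units; beyond the scatter). Compound 4 is accordingly estimated at 400 nM, with a range from 120 nM to 1300 nM.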

Compound 4, concentration for 50% growth inhibition: 630 nM
Compound 4: middle estimate off by 1.6-fold (0.20 log units), on the low side; measured number inside the range.
By their numbers in this assay, from the lowest: compound 1; then compounds 3 and 4 (each within the scatter of the next); then compound 2.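

With the rest of the molecule unchanged, this assay gives the first direct measure of a change on this nitrogen: a 2.1-fold lower number from compound 2 to compound 4 (0.32 log units; beyond the scatter). The step is modest and swaps several features at once, as the ring comes to sit straight on the nitrogen, the chlorine leaves, and the entering 2,4-dimethoxyphenyl carries 2 hydrogen-bond acceptors where 3-chlorobenzyl carries 0. No supporting evidence bears on why the number falls.

From the compounds shown here alone, how much of the step belongs to the lost benzyl carbon and how much to the ring substituents remains open. A 2,4-dimethoxybenzyl or an unsubstituted phenyl on this nitrogen, with the rest of compound 2 kept, would separate these two contributions.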